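The compounds below may be only part of what the source reports. "The series", "measured", "known", "first", "only" and "open" are said of these compounds alone.

Working notes on the series.

Compound 1 `O=C(O)COc1cccc(CCCn2cc(C(c3ccccc3)c3ccccc3)ccc2=O)c1` is the reference point. Among the compounds with values here, in an assay on HEK293 cells for displacement of a labelled ligand from chemoattractant receptor-homologous molecule expressed on Th2 cells (Cavia porcellus), read by scintillation counting, with a stated time of 2 h (on this read-out lower numbers stand for stronger inhibition and higher numbers for weaker inhibition), compound 1 gives 256 nM, and this is the only actual number in the set. Compound 2 `O=C(O)COc1cccc(CCCn2cc(C(c3ccc(Cl)cc3)c3ccc(Cl)cc3)ccc2=O)c1` carries two chlorine substituents on the benzhydryl part of the shared core. In this assay compound 2 returns only a limit rather than a number, > 1000 nM. Thus, of the two values shown, one sits at the assay limit (the limit of > 1000 nM in this assay, at which 1 of the 2 values shown sits), and compound 1 stands alone as the single measured potency; no step between measured compounds can be read from these two.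

Compound 3 `CCC(Oc1cccc(CCCn2cc(C(c3ccccc3)c3ccccc3)ccc2=O)c1)C(=O)O` differs from compound 1 at the acid side chain: ethyl in place of hydrogen on a saturated chain carbon bound to a carbonyl carbon and an oxygen on an aromatic ring. Within the data shown here, no measured step of this kind exists in the set, so the expectation rests on the change itself. A small step is expected, if any, with the ethyl group leaving the acid and its attachment intact; the step from compound 1 to compound 3 is estimated at a 1.2-fold higher number from compound 1 to compound 3 (0.07 log units; within the scatter), within the usual scatter. For compound 3 in this assay the estimate is 300 nM, with a range from 100 nM to 900 nM.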

Compound 3, half-maximal inhibitory concentration: 990 nM
Compound 3: the middle estimate sits 3.3-fold (0.52 log units) below what was measured; measured number above the stated range.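

In this assay, the acid side chain turns out to be a place that responds to substitution: ethyl in place of hydrogen on a saturated chain carbon bound to a carbonyl carbon and an oxygen on an aromatic ring gives a 3.9-fold higher number from compound 1 to compound 3 (0.59 log units; beyond the scatter). Within the data shown here, this is the first step that can be read, and it shows that going from carboxymethoxy to 1-carboxypropoxy is not a silent change, even though the acid stays in the molecule; the step is modest in size and runs towards weaker inhibition. Compound 3 still returns a number, and the only limit in the set belongs to compound 2: the limit of > 1000 nM in this assay, at which 1 of the 3 values shown sits.

With one substituent at this carbon, the compounds shown do not tell whether the step follows the size of the group, so a methyl group, a fluorine atom or a longer chain such as propyl at the same place remains an open case. Also open, going by these compounds, is whether the ethyl change would carry over to a core bearing chlorine substituents on the benzhydryl part.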